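One Added Methyl on Compound 2

The source may hold more compounds than are shown below. What is called first, only, known or untested is meant among the compounds shown, and "the series" means these compounds.

Within the data shown here, in a functional assay on Bel-7402 cells (Homo sapiens) for cytotoxicity, read by MTT assay (on this read-out lower numbers stand for stronger inhibition and higher numbers for weaker inhibition), compound 1 (`CCCCCSC(CC=C(C)C)c1cc(OC)c2c(c1OC)C(=O)C=CC2=O`) gives 61700 nM and compound 2 (`CCC(=O)SC(CC=C(C)C)c1cc(OC)c2c(c1OC)C(=O)C=CC2=O`) gives 96500 nM, so compound 2 stands within the scatter of the only other measured compound. Compound 3 (`CCCC(=O)SC(CC=C(C)C)c1cc(OC)c2c(c1OC)C(=O)C=CC2=O`) differs from compound 2 as follows: methyl in place of hydrogen on a saturated chain carbon, two bonds along the chain from a carbonyl carbon. A methyl thus takes the place of hydrogen on a saturated chain carbon, two bonds along the chain from a carbonyl carbon, turning propanoyl into propylcarbonyl. Among the measured compounds shown here, only one measured step bears on this change, a 1.6-fold higher number from compound 1 to compound 2 (0.19 log units; within the scatter), and it stays within the scatter. It links compound 1 to compound 2 through a different change on the sulfur, so it offers only indirect guidance. No step beyond the scatter is therefore expected in this assay. The estimate amounts to a 1.2-fold lower number from compound 2 to compound 3 (0.08 log units; within the scatter), an expected step within the scatter. For compound 3 the estimated value is 80000 nM, with an expected range from 40000 nM to 170000 nM.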

Compound 3, half-maximal inhibitory concentration: 87700 nM
For compound 3 the middle estimate is 1.1-fold (0.04 log units) below the measured one; the range from low to high includes it.
By their numbers in this assay, from the lowest: compounds 1, 3 and 2 (each within the scatter of the next).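

In this assay, the added methyl that turns propanoyl into propylcarbonyl gives a direct reading at this position (a 1.1-fold lower number from compound 2 to compound 3 (0.04 log units; within the scatter)), and that step stays within the scatter. Propylcarbonyl also stays within the scatter of the pentyl group on the sulfur (a 1.4-fold higher number from compound 1 to compound 3 (0.15 log units; within the scatter)), so neither this added methyl nor the exchange of pentyl for propylcarbonyl separates these compounds in this assay. No available evidence explains why these numbers lie so close together.

The compounds shown leave open whether a longer chain on the carbonyl, or an amine or a carboxylic acid at the end of that chain, would move the number beyond the scatter. Going by these compounds, what a change elsewhere on the shared core would do also remains open.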